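Compound 3 gains a fluoro group

A few compounds are considered here, and "the series" means these few. Any claim that something is new, unique, unknown or untested is made for them only; others in the source may bear on it.

In a physicochemical assay for lipophilicity, using the shake flask method, at pH 7.4 (a higher number here means a more lipophilic compound, a lower number a more polar compound), compound 3 `CCCC(Oc1ccc(-n2cccn2)cc1)c1ccc(C(=O)NCCC(=O)O)cc1` gives 1.7. Two close relatives carry another group on the same aromatic carbon: methoxy in compound 1 `CCCC(Oc1ccc(-n2cc(OC)cn2)cc1)c1ccc(C(=O)NCCC(=O)O)cc1`, which gives 1.4, and cyano in compound 2 `CCCC(Oc1ccc(-n2cc(C#N)cn2)cc1)c1ccc(C(=O)NCCC(=O)O)cc1`, which gives 1.2. Compound 3 sits within the scatter of compound 1 but clearly apart from compound 2.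

The next structure, compound 4 `CCCC(Oc1ccc(-n2cc(F)cn2)cc1)c1ccc(C(=O)NCCC(=O)O)cc1`, has fluoro in place of hydrogen on an aromatic carbon, turning 1H-pyrazol-1-yl into 4-fluoro-1H-pyrazol-1-yl (fluoro in place of hydrogen on an aromatic carbon).

Among the compounds with values here, no fluoro compound has been measured yet, so the guidance is indirect. Two measured steps end at hydrogen on that carbon: a number 0.30 log units higher from compound 1 to compound 3 (within the scatter), and a number 0.50 log units higher from compound 2 to compound 3 (beyond the scatter). Read in reverse, these two cases suggest that a group placed there leaves the number level or lowers it.

The expected change is small and downward, within the scatter, at a number 0.10 log units lower from compound 3 to compound 4 (within the scatter). For compound 4 the estimated value is 1.6, with an expected range from 1.3 to 1.9.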

Compound 4, distribution coefficient: 2
Compound 4: middle estimate off by 0.40 log units, on the low side; the whole stated range lies below it.
By their numbers in this assay, from the lowest: compounds 2, 1, 3 and 4 (each within the scatter of the next, the first and the last beyond it).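

In this assay, within the data shown here, fluoro is the first group on this carbon that stands clear of both other substituents: the step is a number 0.80 log units higher from compound 2 to compound 4 (beyond the scatter) against cyano and a number 0.60 log units higher from compound 1 to compound 4 (beyond the scatter) against methoxy. Hydrogen stands clear only of cyano, so the fluoro compound widens the spread seen at this one position. Against hydrogen itself the step is a number 0.30 log units higher from compound 3 to compound 4 (within the scatter), so that pair cannot be told apart, and swapping hydrogen for fluoro here has no clear effect on the number.

Nothing shown here accounts for these differences between the groups. As far as these compounds go, whether a chlorine atom or a methyl or trifluoromethyl group on this same carbon would fall with fluoro and hydrogen, or with methoxy and cyano, remains open.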